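Selenium-bearing side chains on a shared core

This account rests on a few compounds, and the source may have more. Where it says the series, first, only, none or still open, it means among the compounds named here.

Measured in a functional assay on RKO cells (Homo sapiens) for inhibition, read by MTT assay, with a stated time of 48 h; a lower number here means a stronger inhibitor, a higher number a weaker inhibitor:
- compound 1 `COc1ccc(N(C)c2nc(C)nc3ccccc23)cc1OCC[Se]C#N`: 27 nM
- compound 2 `COc1ccc(N(C)c2nc(C)nc3ccccc23)cc1[Se]C#N`: 47 nM

Only these two values are available, and they cannot be ranked. Compound 2 has the higher number of the pair, but the gap is a 1.7-fold higher number from compound 1 to compound 2 (0.24 log units; within the scatter), so compound 2 stands level with compound 1 in this assay.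

The next compound to be measured is compound 3 `COc1ccc(N(C)c2nc(C)nc3ccccc23)cc1C[Se]C#N`. The change from compound 2 is a group of 4 heavy atoms (2 carbon, 1 nitrogen, 1 selenium; no ring) in place of a group of 3 heavy atoms (1 carbon, 1 nitrogen, 1 selenium; no ring), on an aromatic carbon, at the same aromatic carbon, ortho to a methoxy group.

Going by the values given here, one measured step bears on this change: a 1.7-fold higher number from compound 1 to compound 2 (0.24 log units; within the scatter). It replaced a group of 6 heavy atoms with a group of 3 heavy atoms at that carbon, and the value stayed within the scatter. The group of 4 heavy atoms in compound 3 falls between these two in size, so a value near the pair is expected, although a single step is thin evidence. No step beyond the scatter is expected in this assay, and the estimated step is a 1.3-fold lower number from compound 2 to compound 3 (0.12 log units; within the scatter). For compound 3 the estimated value is 36 nM, with an expected range of 14 nM to 90 nM.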

Compound 3, half-maximal inhibitory concentration: 316 nM
The estimate for compound 3 lay 8.8-fold (0.94 log units) below the measured number; measured number above the stated range.
By their numbers in this assay, from the lowest: compounds 1 and 2 (each within the scatter of the next); then compound 3.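

At this aromatic carbon, ortho to a methoxy group, the side chain does matter in this assay (a 6.7-fold higher number from compound 2 to compound 3 (0.83 log units; beyond the scatter)), a step beyond the scatter, whereas the earlier pair gave no step beyond it. Heavy-atom count does not order the three values: the group of 4 heavy atoms in compound 3 is intermediate in size, yet compound 3 gives the highest number, and the step from the larger group is also beyond the scatter (a 12-fold higher number from compound 1 to compound 3 (1.07 log units; beyond the scatter)), so what joins the selenium to the ring, not group size alone, separates these compounds. No measurement bears on the origin of this loss of inhibition.

Three compounds cannot show whether the higher number belongs to the single carbon link itself or would persist with a longer carbon chain, or with an oxygen or amine link of the same length. The role of selenium also remains open, since every side chain shown ends in the same selenium-nitrile unit, and a sulfur-nitrile or plain nitrile group at this carbon would be needed to separate selenium from the rest of the side chain.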